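A few compounds are considered here, and "the series" means these few. Any claim that something is new, unique, unknown or untested is made for them only; others in the source may bear on it.

Working notes on the series. Of the compounds shown here, two have been measured in an assay on membranes from HEK293 cells for displacement of a labelled ligand from adenosine receptor A2b (Homo sapiens), read by scintillation counting, with a stated time of 30 min; on this read-out lower numbers stand for stronger inhibition and higher numbers for weaker inhibition. Compound 1 `CC1=C(C(=O)OCC2CCC2)C(c2cccs2)NC(=O)N1` gives 2840 nM. Compound 2 `CC1=C(C(=O)OC2CCC2)C(c2ccsc2)NC(=O)N1` gives 405 nM, the lower of the two numbers. Compound 3 `CC1=C(C(=O)OCC2CCC2)C(c2ccsc2)NC(=O)N1` is compound 2 with cyclobutylmethyl in place of cyclobutyl on an oxygen next to a carbonyl group. Compound 1 carries the same ester as compound 3, but it also differs from compound 2 elsewhere in the structure, so no single change between measured compounds is available and its value serves only as a rough guide. For compound 3 a modest weakening is expected, a 2.2-fold higher number from compound 2 to compound 3 (0.35 log units; beyond the scatter). The estimate for compound 3 in this assay is 900 nM, within 300 nM to 2700 nM.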

Compound 3, inhibition constant: 1040 nM
Estimate against measurement, compound 3: 1.2-fold (0.06 log units) below; measured number inside the range.
By their numbers in this assay, from the lowest: compound 2; then compound 3; then compound 1.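

In this assay the change to cyclobutylmethyl in place of cyclobutyl on an oxygen next to a carbonyl group gives a 2.6-fold higher number from compound 2 to compound 3 (0.41 log units; beyond the scatter) as a single-place step, so this position alone shifts the number. The second step, thiophen-3-yl in place of thiophen-2-yl on a saturated ring carbon, gives a 2.7-fold lower number from compound 1 to compound 3 (0.44 log units; beyond the scatter) and shows that the number of compound 1 does not rest on its ester alone. No measurement at hand accounts for either step.

Open, from the compounds shown here alone, is how a longer chain or an amine on that oxygen would read. Also open, going by these compounds, is whether the thiophene step holds with the cyclobutyl ester.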